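Exposure of compound 4 after a sulfur-bearing group swap

The compounds below may be only part of what the source reports. "The series", "measured", "known", "first", "only" and "open" are said of these compounds alone.

Values in an ADME assay on the whole organism (Mus musculus, strain CD-1) for pharmacokinetics, at a dose of 10 mg/kg by the oral route; on this read-out higher numbers stand for higher exposure at the dose given and lower numbers for lower exposure:
- compound 1 `CCCOc1cc([C@](O)(CCN(C)C)[C@@H](c2cc3cc(Br)ccc3nc2OC)c2ccnc(OC)c2OC)cc(OC)n1`: 10900 ng.h/mL
- compound 2 `COc1cc([C@](O)(CCN(C)C)[C@@H](c2cc3cc(Br)ccc3nc2OC)c2cccc(OC)c2F)cc(OC(F)F)n1`: 14400 ng.h/mL
- compound 3 `COc1cc([C@](O)(CCN(C)C)[C@@H](c2cc3cc(Br)ccc3nc2OC)c2ccnc(OC)c2OC)cc(OC(F)F)n1`: 9800 ng.h/mL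

Compound 2, at 14400 ng.h/mL, stands together with the other two compounds, and no gap among the three goes beyond the usual scatter. Compound 4 `CCSc1cc([C@](O)(CCN(C)C)[C@@H](c2cc3cc(Br)ccc3nc2OC)c2cccc(OC)c2F)cc(SCC)n1` has not yet been measured in this assay. It differs from compound 2 in one place: a group of 12 heavy atoms (9 carbon, 1 nitrogen, 2 sulfur; one six-membered aromatic ring with 1 hetero atom) in place of a group of 12 heavy atoms (7 carbon, 1 nitrogen, 2 oxygen, 2 fluorine; one six-membered aromatic ring with 1 hetero atom), on a saturated chain carbon bound to an oxygen on a saturated carbon and two saturated chain carbons.

Among the measured compounds shown here, two measured steps bear on this change, and only in part. The closer one is a 1.1-fold lower number from compound 1 to compound 3 (0.05 log units; within the scatter), with difluoromethyl in place of propyl on an oxygen on an aromatic ring, so it alters the kind of group that leaves here. The other is a 1.5-fold lower number from compound 2 to compound 3 (0.17 log units; within the scatter), which lies at a different place in the structure. Both stay within the scatter. For the measured compounds named here, no measured compound carries sulfur, so the data do not show how such a group behaves, and the range must stay wide.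

With nothing pointing to a clear direction, no step beyond the scatter is expected. The expected change is a 1.4-fold lower number from compound 2 to compound 4 (0.16 log units; within the scatter). For compound 4 the estimated value is 10000 ng.h/mL, with an expected range of 4000 ng.h/mL to 22000 ng.h/mL.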

Compound 4, area under the concentration-time curve: 11900 ng.h/mL
Compound 4: middle estimate off by 1.2-fold (0.08 log units), on the low side, within the range that was stated.
By their numbers in this assay, from the lowest: compounds 3, 1, 4 and 2 (each within the scatter of the next).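

In this assay, a 1.2-fold lower number from compound 2 to compound 4 (0.08 log units; within the scatter), so exchanging the group of 7 carbon, 1 nitrogen, 2 oxygen and 2 fluorine for the group of 9 carbon, 1 nitrogen and 2 sulfur, on the saturated chain carbon bound to an oxygen on a saturated carbon and two saturated chain carbons, produces no step beyond the scatter. The earlier compounds shown here showed only groups without sulfur at this place, and compound 4 now extends the set of groups there that stay within the scatter of compound 2 to one that carries sulfur and no oxygen or fluorine. Nothing given here accounts for this result, and the step says only how large the exposure difference is, not what lies behind it.

The change replaces the whole group in one step, so the compounds shown leave open how much each sulfur-bearing part contributes on its own. They also leave open whether a group with an amine or a carboxylic acid on the same six-membered aromatic ring would stay within the scatter of compound 2.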